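This account rests on a few compounds, and the source may have more. Where it says the series, first, only, none or still open, it means among the compounds named here.

Three compounds here share one core. Compound 1 `COc1ccc(CNc2cc(OC)c(OC)c(OC)c2)cc1C` gives 73800 nM in a functional assay on KYSE-450 cells (Homo sapiens) for inhibition, read by MTT assay, with a stated time of 48 h; on this read-out higher numbers stand for weaker inhibition and lower numbers for stronger inhibition; compound 2 `COC(=O)c1cc(CNc2cc(OC)c(OC)c(OC)c2)ccc1OC` gives 41100 nM; compound 3 `COc1ccc(CNc2cc(OC)c(OC)c(OC)c2)cc1` gives 4890 nM, the lowest of the three numbers, and its gaps to the other two lie beyond the scatter. The step of a 15-fold lower number from compound 1 to compound 3 (1.18 log units; beyond the scatter) and the step of an 8.4-fold lower number from compound 2 to compound 3 (0.92 log units; beyond the scatter) both describe removing a group from the same aromatic carbon, and both lowered the number, while a 1.8-fold lower number from compound 1 to compound 2 (0.25 log units; within the scatter) shows little difference between the two substituted compounds. Compound 4 `COc1ccc(CNc2cc(OC)c(OC)c(OC)c2)cc1[N+](=O)[O-]` places a new group on that carbon: nitro in place of hydrogen on an aromatic carbon. The two measured steps are the ones that bear on this change, and because a 15-fold lower number from compound 1 to compound 3 (1.18 log units; beyond the scatter) and an 8.4-fold lower number from compound 2 to compound 3 (0.92 log units; beyond the scatter) both run in the same direction, an upward step beyond the scatter is expected, of roughly the size those two groups produced. In this assay compound 4 is therefore estimated at 40000 nM, with a range from 10000 nM to 150000 nM. The expected change is an 8.2-fold higher number from compound 3 to compound 4 (0.91 log units; beyond the scatter).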

Compound 4, half-maximal inhibitory concentration: 16800 nM
For compound 4 the middle estimate is 2.4-fold (0.38 log units) above the measured one; low and high end bracket the measured number.
By their numbers in this assay, from the lowest: compound 3; then compound 4; then compounds 2 and 1 (each within the scatter of the next).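

In this assay nitro is a third group on this aromatic carbon that gives a higher number than hydrogen, with a 3.4-fold higher number from compound 3 to compound 4 (0.54 log units; beyond the scatter) as the step, so among the four compounds hydrogen still gives the lowest number. The new result also shows that the groups placed here are not interchangeable, since a 2.4-fold lower number from compound 2 to compound 4 (0.39 log units; beyond the scatter) and a 4.4-fold lower number from compound 1 to compound 4 (0.64 log units; beyond the scatter) both lie beyond the scatter, while methyl and methoxycarbonyl could not be told apart. The size of the rise from hydrogen therefore depends on which group enters, at least across these three groups.

As far as these compounds go, whether an amine or a carboxylic acid on this carbon would also raise the number, or would match hydrogen, stays open. Nothing given here explains the differences among these groups.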